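Swapping Ethyl for Fluoro on a Growth Inhibitor

A few compounds are considered here, and "the series" means these few. Any claim that something is new, unique, unknown or untested is made for them only; others in the source may bear on it.

- Compound 1 `CCc1ccc(SCc2ccc(C(=O)Nc3ccccc3N)cc2)cc1`: 82.9%
- Compound 2 `Nc1ccccc1NC(=O)/C=C/c1ccc(CSc2cccc3ccccc23)cc1`: 18.3%
- Compound 3 `COc1ccc(SCc2ccc(C(=O)Nc3ccccc3N)cc2)cc1OC`: 78.9%

In a functional assay on SMMC-7721 cells (Homo sapiens) for inhibition, read by CCK-8 assay, with a stated time of 72 h, tested at 8 uM (on this read-out lower numbers stand for less inhibition of growth and higher numbers for more inhibition of growth at the one concentration tested), compound 1 gives 82.9%. That places it level with compound 3 within the scatter and far beyond compound 2. The next compound to be measured is compound 4 `Nc1ccccc1NC(=O)c1ccc(CSc2ccc(F)cc2)cc1`, which carries fluoro in place of ethyl on an aromatic carbon. Among the compounds with values here, no measured pair isolates this kind of change, so the expectation is tentative. Compound 3 also carries different groups on this ring and still gives 78.9%, which suggests no large loss. A small expected drop, a number 8.9 percentage points lower from compound 1 to compound 4 (within the scatter), would stay within the scatter. The estimated value for compound 4 is 74%, with an expected range of 48% to 90%.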

Compound 4, percent growth inhibition at one concentration: 81.9%
The estimate for compound 4 lay 7.9 percentage points below the measured number; low and high end bracket the measured number.
By their numbers in this assay, from the lowest: compound 2; then compounds 3, 4 and 1 (each within the scatter of the next).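

In this assay, within the data shown here, fluoro in place of ethyl on an aromatic carbon, para to a large group, gives a number 1 percentage points lower from compound 1 to compound 4 (within the scatter) and is the first single change at this position that can be read. At the one concentration tested, this position takes either ethyl or fluoro without a change that stands out from the scatter. No measurement is available that could explain this result.

As far as these compounds go, whether an amine, a carboxylic acid or a longer chain such as butyl would fit here equally well stays open. From the compounds shown here alone, whether ethyl and fluoro would still match at lower concentrations also stays open.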